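The source may report more compounds than this note shows. Statements on the series, on what has been measured and on what is new or still open speak of the compounds shown alone.

Measured so far:
compound 1 `Clc1ccccc1-c1nnn(CCCn2cnc3c(Br)c(Br)c(Br)c(Br)c32)n1` gives 42% in a functional assay on CCRF-CEM cells (Homo sapiens) for cytotoxicity, read by MTT assay, with a stated time of 48 h, tested at 50 uM; on this read-out higher numbers stand for a weaker effect at the one concentration tested and lower numbers for a stronger effect
compound 2 `Brc1c(Br)c(Br)c2c(ncn2CCCn2nnnc2-c2ccccc2)c1Br` gives 0% in this assay

Compound 2 stands lowest of the two numbers in this assay; compound 1 sits higher by a margin beyond the scatter. Compound 3 `Clc1ccccc1-c1nnnn1CCCn1cnc2c(Br)c(Br)c(Br)c(Br)c21` is not yet measured. It differs from compound 2 by chloro in place of hydrogen on an aromatic carbon. Within the data shown here, no step between measured compounds that differ in one place is available, so the size of the effect is uncertain; compound 1 carries a chloro group as well and gives 42% in this assay, which is the only hint. An upward step a number 25 percentage points higher from compound 2 to compound 3 (beyond the scatter) is expected, of moderate size. The estimate for compound 3 in this assay is 25%, range 0% to 50%.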

Compound 3, a percentage reported as inhibition, at one concentration (the size of the read-out at that concentration, not a potency): 0%
Compound 3: the middle estimate sits 25 percentage points above what was measured; measured number inside the range.
By their numbers in this assay, from the lowest: compounds 2 and 3 (each within the scatter of the next); then compound 1.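

In this assay, among these compounds, the change from phenyl to 2-chlorophenyl gives no change at the digits printed from compound 2 to compound 3 (within the scatter) and is the first step that can be read. At this place, on an aromatic carbon ortho to a large group, chloro in place of hydrogen leaves the read-out unmoved. No available data explain this flat step. Still open, from the compounds shown here alone, is whether a different group at this place, such as methoxy, an amine or a carboxylic acid, would move the read-out. Also open, going by these compounds, is whether a longer chain in place of the propyl linker would change it.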